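Bromo for isobutoxy on the aromatic carbon: cytotoxicity notes

The compounds below may be only part of what the source reports. "The series", "measured", "known", "first", "only" and "open" are said of these compounds alone.

Measured compounds:
compound 1, `CCOC(=O)c1c(-c2ccccc2)[nH]c2cc(OC)ccc2c1=O`: > 21500 nM
compound 2, `CCOC(=O)c1c(-c2cccc(OCC(C)C)c2)[nH]c2cc(OC)ccc2c1=O`: > 21500 nM

In an ADME assay on HepG2 cells (Homo sapiens) for cytotoxicity, read by luminescence, with a stated time of 72 h (a higher number here means that more compound is needed for the effect, a lower number that less compound is needed), compound 1 gives > 21500 nM, which is a limit of the assay and not a number. Compound 2 gives > 21500 nM in this assay, again a limit rather than a number. The step that the two limits leave unreadable from compound 1 to compound 2 therefore cannot be sized, since the limit of > 21500 nM in this assay, at which 2 of the 2 values shown sit, holds both values shown. Among the measured compounds shown here, compound 2 thus stands at the limit, as does every value so far.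

Compound 3, `CCOC(=O)c1c(-c2cccc(Br)c2)[nH]c2cc(OC)ccc2c1=O`, differs from compound 2 by bromo in place of isobutoxy on an aromatic carbon. For the measured compounds named here, the only measured step that touches this part of the structure is the one from compound 1 to compound 2, and it is unreadable, so nothing here sets a size for the change from isobutoxy to bromo. Compound 3 is expected to behave like compound 2, with a step that the limit leaves unreadable from compound 2 to compound 3 in this assay that is expected to stay within the scatter. Compound 3 is estimated at 30000 nM, with a range from 10000 nM to 100000 nM, and most likely it too is expected to return only a limit.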

Compound 3, half-maximal effective concentration: > 21500 nM
Compound 3: no number, only a limit; the forecaster's own chance of this, stated with the estimate: 70%; the middle value does not contradict the limit.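

No step among compound 1, compound 2 and compound 3 can be read in this assay, since each value is a limit of the assay and not a number: the limit of > 21500 nM in this assay, at which 3 of the 3 values shown sit.

The compounds shown leave open whether hydrogen, isobutoxy or bromo on the aromatic carbon makes any difference in this assay, and how far each compound lies from that limit.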